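Urea to benzamide on an inactive pyrazole scaffold

The source may report more compounds than this note shows. Statements on the series, on what has been measured and on what is new or still open speak of the compounds shown alone.

Compound 1: `O=C(Nc1cccc(-n2cc(-c3ccncc3)c(-c3ccc(Cl)c(O)c3)n2)c1)Nc1cccc(C(F)(F)F)c1` — > 32500 nM
Compound 2: `COc1cc(-c2nn(-c3cccc(NC(=O)Nc4cccc(C(F)(F)F)c4)c3)cc2-c2ccncc2)ccc1Cl` — > 50000 nM

In a functional assay on NCI-H226 cells (Homo sapiens) for inhibition, read by sulforhodamine B assay, with a stated time of 48 h (on this read-out lower numbers stand for higher toxicity in this test and higher numbers for lower toxicity in this test), compound 1 gives a value that is a limit of the assay, (the limit of > 32500 nM in this assay, at which 1 of the 2 values shown sits). Compound 2 likewise gives only a limit, (the limit of > 50000 nM in this assay, at which 1 of the 2 values shown sits). The step that the two limits leave unreadable from compound 1 to compound 2 is therefore unreadable, and compound 2 stands at a limit with no number of its own. Compound 3, `COc1cc(-c2nn(-c3cccc(NC(=O)c4ccccc4)c3)cc2-c2ccncc2)ccc1Cl`, differs from compound 2 by phenyl in place of (3-(trifluoromethyl)phenyl)amino on a carbonyl carbon, so the urea becomes a benzamide and the trifluoromethyl group is lost. Among the measured compounds shown here, no measured step touches this change, and neither measured compound shows toxicity within the tested range. Compound 3 is therefore expected to remain beyond the scatter only in the sense of staying inactive, with an estimated value of 60000 nM and a range from 20000 nM to 200000 nM. The step that the limit leaves unreadable from compound 2 to compound 3 that this estimate means is expected to be no real change, and most likely compound 3 will again be reported only as a limit.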

Compound 3, concentration lethal to 50% of the cells: > 100000 nM
Compound 3 gave a limit, no number; the forecaster's own chance of this, stated with the estimate: 80%; middle value at least 1.6-fold (0.22 log units) from the limit.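

In this assay compound 3 gives > 100000 nM, which is a limit of the assay. Among the compounds shown here, compound 2 also stands only at a limit, so no step between compound 2 and compound 3 can be read. The compounds shown leave open what replacing the urea with the benzamide does to a measurable value in this assay.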